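This account rests on a few compounds, and the source may have more. Where it says the series, first, only, none or still open, it means among the compounds named here.

Of the compounds shown here, three of one shared core have been measured in a functional assay on A549 cells (Homo sapiens) for cytotoxicity, read by WST assay, with a stated time of 72 h; on this read-out lower numbers stand for stronger inhibition and higher numbers for weaker inhibition. Compound 1 `COc1cc2c(Nc3nc4ccc(C(=O)Nc5c(C)cc(C)cc5C)cc4s3)ncnc2cc1OCCCN1CCCCC1` gives 10300 nM. Compound 2 `COc1cc2c(Nc3nc4ccc(C(=O)Nc5c(C)cccc5C)cc4s3)ncnc2cc1OCCCN1CCC(C)CC1` gives 89700 nM, the highest number of the three: its nearest neighbour is compound 3 `COc1cc2c(Nc3nc4ccc(C(=O)Nc5c(C)cccc5C)cc4s3)ncnc2cc1OCCCN1CCCC1`, which gives 83800 nM, a gap within the scatter, while the gap to compound 1 lies beyond it. Among the compounds with values here, the single one-place step available, a 1.1-fold lower number from compound 2 to compound 3 (0.03 log units; within the scatter), concerns the amine ring at the end of the chain and is flat. Compound 4 `COc1cc2c(Nc3nc4ccc(C(=O)Nc5c(C)cc(C)cc5C)cc4s3)ncnc2cc1OCCCN1CCC(C)CC1` is now to be measured. It differs from compound 2 by methyl in place of hydrogen on an aromatic carbon. Within the data shown here, no measured step isolates this change; compound 1 carries the same 2,4,6-trimethylphenyl group but also a different amine ring, and its two values against compound 2 differ by far more than the flat amine step. Compound 4 is therefore expected to sit well below compound 2, by about a 6.0-fold lower number from compound 2 to compound 4 (0.78 log units; beyond the scatter). The estimate for compound 4 in this assay is 15000 nM, with a range from 5000 nM to 45000 nM.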

Compound 4, half-maximal inhibitory concentration: 5400 nM
Compound 4: middle estimate off by 2.8-fold (0.44 log units), on the high side; the measured number falls inside the stated range.
By their numbers in this assay, from the lowest: compounds 4 and 1 (each within the scatter of the next); then compounds 3 and 2 (each within the scatter of the next).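

In this assay, methyl in place of hydrogen on the aromatic carbon para to a large group, which turns 2,6-dimethylphenyl into 2,4,6-trimethylphenyl, gives a 17-fold lower number from compound 2 to compound 4 (1.22 log units; beyond the scatter), so this single carbon carries a large step where the amine ring end has so far carried none. The amine ring stays flat with the 2,4,6-trimethylphenyl group too: methyl in place of hydrogen on a saturated ring carbon gives a 1.9-fold lower number from compound 1 to compound 4 (0.28 log units; within the scatter), which is within the scatter, as is a 1.1-fold lower number from compound 2 to compound 3 (0.03 log units; within the scatter) with the 2,6-dimethylphenyl group. Nothing available explains why this one methyl matters so much.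

The compounds shown leave open whether an ethyl group, a methoxy group or a chlorine atom on the same aromatic carbon would give a step of similar size. They also leave open whether the step depends on the two methyl groups that stay in place, which a phenyl ring lacking them would test.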